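This account rests on a few compounds, and the source may have more. Where it says the series, first, only, none or still open, it means among the compounds named here.

Measured so far:
compound 1 `O=c1ccoc(/C=C/c2ccccc2)c1`, 509 uM in a functional assay on NCI-H460 cells (Homo sapiens) for inhibition, read by sulforhodamine B assay, with a stated time of 48 h; a higher number here means a weaker inhibitor of growth, a lower number a stronger inhibitor of growth
compound 2 `COc1ccc(/C=C/c2cc(=O)cco2)cc1`, 606 uM in this assay
compound 3 `COc1ccc(/C=C/C2CC=CC(=O)O2)cc1`, 28.3 uM in this assay

Compound 1 and compound 2 share a core and differ by methoxy in place of hydrogen on an aromatic carbon; the step is a 1.2-fold higher number from compound 1 to compound 2 (0.08 log units; within the scatter). Compound 3 carries a different core; the difference between the two cores is not broken down here. What the values show is that compound 3 gives the lowest number of the three, with compound 1 and compound 2 both well beyond the scatter from it.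

Compound 4 `COc1ccc(/C=C/C2CC=CC(=O)O2)c(OC)c1` has not been measured. It differs from compound 3 by methoxy in place of hydrogen on an aromatic carbon. This is the same kind of change as that from compound 1 to compound 2, but the surroundings differ: in the earlier pair the entering group sits para to the group of 9 heavy atoms, whereas here it sits ortho to that group and meta to a methoxy group. In this assay the step expected from compound 3 to compound 4 is a 1.1-fold higher number from compound 3 to compound 4 (0.03 log units; within the scatter), beside the earlier 1.2-fold higher number from compound 1 to compound 2 (0.08 log units; within the scatter), because the step of a 1.2-fold higher number from compound 1 to compound 2 (0.08 log units; within the scatter) lay within the scatter. Compound 4 is thus expected to give about 30 uM, estimated between 12 uM and 75 uM.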

Compound 4, concentration for growth inhibition (reported as GI): 6 uM
Compound 4: the middle estimate sits 5.0-fold (0.70 log units) above what was measured; the whole stated range lies above it.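

In this assay, methoxy in place of hydrogen on an aromatic carbon gives a 4.7-fold lower number from compound 3 to compound 4 (0.67 log units; beyond the scatter), a step that does not match the one seen on the core of compound 1. The size of this change therefore does not carry from one core to the other in this series: the same change on two cores in this assay, a 1.2-fold higher number (0.08 log units; within the scatter) from compound 1 to compound 2 and a 4.7-fold lower number (0.67 log units; beyond the scatter) from compound 3 to compound 4, 5.6-fold (0.75 log units) apart, beyond the scatter of two such steps

What stays unshown is the source of the gap: the two pairs differ in their core and also in where the methoxy enters, here ortho to a group of 9 heavy atoms and meta to a methoxy group, and two pairs cannot separate these differences.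

Open, on these data alone, is whether methoxy at this same place on the core of compound 1 would give a step like that to compound 4, which would point to the place rather than the core. Also open, as far as these compounds go, is whether a hydroxyl group, a fluorine atom or a longer chain such as ethoxy at that place would give a number like that of compound 4.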